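A few compounds are considered here, and "the series" means these few. Any claim that something is new, unique, unknown or untested is made for them only; others in the source may bear on it.

Compound 1 `Oc1cccc(Nc2nc(NCc3ccccc3)c3ccccc3n2)c1` stands highest of the two compounds measured. In a functional assay on SK-OV-3 cells (Homo sapiens) for inhibition, read by MTT assay, tested at 100 uM (on this read-out higher numbers stand for more inhibition at the one concentration tested (going by the name of the read-out) and lower numbers for less inhibition), compound 1 gives 85.5%. Compound 2 `CCC(C)(C)c1ccc(O)c(NS(=O)(=O)c2ccccc2OC(F)(F)F)c1` is built quite differently, and in this assay compound 2 gives 46.4%, so compound 1 sits above it by a margin beyond the usual scatter. Compound 3 `Fc1ccc(Nc2nc(NCc3ccccc3)c3ccccc3n2)cc1` keeps the core of compound 1 and differs from it in a single place: 4-fluorophenyl in place of 3-hydroxyphenyl on a nitrogen on an aromatic ring. Among the compounds with values here, nothing measured here shows how a swap of this kind plays out in this assay, since no two measured compounds differ from each other in only one place. The expectation for compound 3 therefore rests on compound 1 alone, with the hydroxyphenyl replaced by fluorophenyl, and a moderate fall is expected, a number 15.5 percentage points lower from compound 1 to compound 3 (beyond the scatter), though a result lying within the scatter of compound 1 would not be surprising. Compound 3 is estimated to reach 70% in this assay, with a likely range from 40% to 92%.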

Compound 3, a percentage reported as inhibition, at one concentration (the size of the read-out at that concentration, not a potency): 91.3%
Compound 3: middle estimate off by 21.3 percentage points, on the low side, and the stated range covers the measured number.
By their numbers in this assay, from the lowest: compound 2; then compounds 1 and 3 (each within the scatter of the next).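

In this assay, putting 4-fluorophenyl in place of 3-hydroxyphenyl on a nitrogen on an aromatic ring gives a number 5.8 percentage points higher from compound 1 to compound 3 (within the scatter) and so leaves the two compounds indistinguishable on this read-out. This first one-place comparison shows that, on the core of compound 1, the hydroxyl is not needed for this level of inhibition at the one concentration tested, even though the 3-hydroxyphenyl counts 1 hydrogen-bond donor and 1 hydrogen-bond acceptor and the 4-fluorophenyl counts 0 of each. Nothing available explains why the two compounds read alike.

The change replaces the hydroxyl with fluorine and also alters the numbered place of the group on the phenyl ring, so these two differences cannot be separated using the compounds shown, and a single-concentration reading does not show whether their potencies match. As far as these compounds go, it also remains open whether an unsubstituted phenyl, or a phenyl carrying an amine or a carboxylic acid, would read within the scatter of compound 1 and compound 3 on that same nitrogen.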